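Swapping one indolyl group for another on compound 2

This account rests on a few compounds, and the source may have more. Where it says the series, first, only, none or still open, it means among the compounds named here.

In a functional assay on MCF7 cells (Homo sapiens) for inhibition, read by CCK-8 assay, with a stated time of 48 h (a higher number here means a weaker inhibitor, a lower number a stronger inhibitor), compound 1 `COc1cc(-c2ccnc3cc(-c4ccc(Cl)cc4)nn23)cc(OC)c1OC` gives 2320 nM and compound 2 `COc1cc(-c2ccnc3cc(-c4ccc5c(ccn5C)c4)nn23)cc(OC)c1OC` gives 3 nM, the lower of the two numbers. Compound 3 `COc1cc(-c2ccnc3cc(-c4ccc5cc[nH]c5c4)nn23)cc(OC)c1OC` keeps the shared core and carries 1H-indol-6-yl in place of 1-methyl-1H-indol-5-yl on an aromatic carbon. For the measured compounds named here, one measured step bears on this change: a 770-fold lower number from compound 1 to compound 2 (2.89 log units; beyond the scatter), when 1-methyl-1H-indol-5-yl replaced 4-chlorophenyl at the same place. That large step shows that the group here can move the number strongly, but it does not directly test an exchange between two groups with the same ring types. With compound 2 at 3 nM, a moderate upward step is expected, estimated as a 6.7-fold higher number from compound 2 to compound 3 (0.82 log units; beyond the scatter). Compound 3 is estimated at 20 nM, with an expected range of 3 nM to 130 nM.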

Compound 3, half-maximal inhibitory concentration: 23 nM
For compound 3 the middle estimate is 1.2-fold (0.06 log units) below the measured one; the range from low to high includes it.
By their numbers in this assay, from the lowest: compound 2; then compound 3; then compound 1.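

In this assay, exchanging one indolyl group for another at this place gives a 7.7-fold higher number from compound 2 to compound 3 (0.88 log units; beyond the scatter), so the number responds beyond the scatter even when the ring types stay the same. Compound 3 still shows a 100-fold lower number from compound 1 to compound 3 (2.00 log units; beyond the scatter), so a large drop from the 4-chlorophenyl compound is not confined to 1-methyl-1H-indol-5-yl; 1H-indol-6-yl, with its hydrogen-bond donor, gives one too. Nothing at hand offers a reason for the difference between the two indolyl groups.

Compound 2 and compound 3 differ both in the methyl group on the ring nitrogen and in the point of attachment, and the compounds shown cannot separate these two changes. From the compounds shown here alone, a 1H-indol-5-yl group at this place would part them, and how an indolyl ring bearing an amine or a carboxylic acid would fare remains open.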